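The source may hold more compounds than are shown below. What is called first, only, known or untested is meant among the compounds shown, and "the series" means these compounds.

Measured in an ADME assay on Huh-7 cells (Homo sapiens) for cytotoxicity, with a stated time of 72 h; a higher number here means that more compound is tolerated, a lower number that less compound is tolerated:
- Compound 1 `CC(C)CCn1nc(-c2cccs2)c(O)c(C2=NS(=O)(=O)c3cc(CS(C)(=O)=O)ccc3N2)c1=O`: > 33000 nM (a limit)
- Compound 2 `CS(=O)(=O)Nc1ccc2c(c1)S(=O)(=O)N=C(c1c(O)c(-c3ccsc3)nn(CCC3CC3)c1=O)N2`: > 1000 nM (a limit)
- Compound 3 `CC(C)CCn1nc(C2CCCCC2)c(O)c(C2=NS(=O)(=O)c3cc(NS(C)(=O)=O)ccc3N2)c1=O`: > 1000 nM (a limit)

All three results are limits rather than exact numbers, and no two of these compounds differ in only one place. Within the data shown here, no measured step therefore shows what a single structural change does here.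

The next compound to consider is compound 4 `C/C(=C\c1nn(CCC(C)C)c(=O)c(C2=NS(=O)(=O)c3cc(NS(C)(=O)=O)ccc3N2)c1O)C(F)(F)F`, which has not yet been measured. It differs from compound 3 in one place: 2-(trifluoromethyl)prop-1-en-1-yl in place of cyclohexyl on an aromatic carbon.

Compound 3 gives > 1000 nM in this assay, which is a limit and not a number. With only this limit as a starting point, a modest upward step is expected for this change, and a clear drop is not expected. The estimated change is a step that the limit leaves unreadable from compound 3 to compound 4. Compound 4 may well be reported only as a limit too. For compound 4 the expected value is 5000 nM, with an estimated range of 1000 nM to 33000 nM.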

Compound 4, half-maximal cytotoxic concentration: > 33000 nM
Compound 4 gave a limit, no number; the forecaster's own chance of this, stated with the estimate: 85%; middle value at least 6.6-fold (0.81 log units) from the limit.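

Compound 3 and compound 4 are both reported only as limits, not as numbers, so the step between them cannot be read. The compounds shown leave open what any single structural change, including 2-(trifluoromethyl)prop-1-en-1-yl in place of cyclohexyl, does to cytotoxicity.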